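Loss of the bromo group in a weakly cytotoxic pair

A few compounds are considered here, and "the series" means these few. Any claim that something is new, unique, unknown or untested is made for them only; others in the source may bear on it.

Two measured compounds share one core and differ only in the group carried on the ring nitrogen. Compound 1 `CCN(CC)CN1C(=O)C(=O)c2c(Br)cccc21` carries a diethylaminomethyl group; in an ADME assay on MCF-10A cells (Homo sapiens) for cytotoxicity, read by sulforhodamine B assay, with a stated time of 48 h (a higher number here means a weaker inhibitor of growth, a lower number a stronger inhibitor of growth), compound 1 gives 113000 nM. Compound 2 `O=C1C(=O)N(CN(c2ccccc2)c2ccccc2)c2cccc(Br)c21` carries a diphenylaminomethyl group, and in this assay compound 2 gives 85800 nM. Compound 2 thus holds the lower of the two numbers, but compound 1 lies within the scatter of it, so no order between the two is claimed; both are weak inhibitors of growth on this cell line.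

Compound 3 `O=C1C(=O)N(CN(c2ccccc2)c2ccccc2)c2ccccc21` keeps the diphenylaminomethyl group of compound 2 and differs from it in one place: hydrogen in place of bromo on an aromatic carbon. Among the measured compounds shown here, no step between measured compounds is available, so the effect of this change in this assay is not known from the series itself. With both measured compounds sitting at weak inhibition, the step from compound 2 to compound 3 is expected to stay within the scatter, if anything toward a slightly higher number, as a 1.2-fold higher number from compound 2 to compound 3 (0.09 log units; within the scatter). Compound 3 is therefore estimated at 105000 nM, with a range from 40000 nM to 280000 nM.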

Compound 3, concentration for 50% growth inhibition: 73000 nM
For compound 3 the middle estimate is 1.4-fold (0.16 log units) above the measured one, within the range that was stated.
By their numbers in this assay, from the lowest: compounds 3, 2 and 1 (each within the scatter of the next).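

In this assay, among the compounds shown here, hydrogen in place of bromo on an aromatic carbon gives a 1.2-fold lower number from compound 2 to compound 3 (0.07 log units; within the scatter) and this is the only step that reads this position on its own, with the diphenylaminomethyl group held fixed. The earlier pair varied only the group on the ring nitrogen, whereas this step shows that the bromo group at this carbon, ortho to a fused ring and meta to a fused ring, is not required for the weak growth inhibition seen on these cells when the diphenylaminomethyl group is present. No measurement is available that would account for this result.

On these data alone, the step covers the diphenylaminomethyl pair only, so whether hydrogen in place of bromo would read the same way with the diethylaminomethyl group of compound 1 remains open. Also open, as far as these compounds go, is how other groups on this aromatic carbon, such as a chlorine atom, a methoxy group or a carboxylic acid, would compare with bromo and hydrogen, and whether any of them would give a number beyond the scatter of these values.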